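Thiomorpholine urea on the piperidine amide scaffold

The source may hold more compounds than are shown below. What is called first, only, known or untested is meant among the compounds shown, and "the series" means these compounds.

Measured compounds:
compound 1 `CC(C)(C)c1cc(NC(=O)[C@@H]2CCCCN2C(=O)C2CCCCC2)no1` gives 6.4 ug/mL
compound 2 `CC(=O)N1CCN(C(=O)N2CCCC[C@H]2C(=O)Nc2cc(C(C)(C)C)on2)CC1` gives 62 ug/mL

Going by the values given here, compound 2 stands highest of the two numbers in a physicochemical assay for solubility, read by HPLC, at pH 6.8; on this read-out higher numbers stand for higher solubility and lower numbers for lower solubility; its nearest neighbour is compound 1, and the one measured step, a 9.7-fold higher number from compound 1 to compound 2 (0.99 log units; beyond the scatter), came from putting 4-acetylpiperazin-1-yl in place of cyclohexyl on a carbonyl carbon. Compound 3 `CC(C)(C)c1cc(NC(=O)[C@@H]2CCCCN2C(=O)N2CCSCC2)no1` is the untested member. It differs from compound 2 in one place: thiomorpholin-4-yl in place of 4-acetylpiperazin-1-yl on a carbonyl carbon. That step bears the same carbonyl carbon as the measured step, and it removes the group that carried compound 2 above compound 1 while bringing in a ring that sits between the two measured cases in character. A fall from compound 2 is therefore expected, though not back to the level of compound 1. For compound 3 the expected step is a 4.1-fold lower number from compound 2 to compound 3 (0.62 log units; beyond the scatter). The estimate for compound 3 in this assay is 15 ug/mL, with a range from 5 ug/mL to 45 ug/mL.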

Compound 3, solubility: 46 ug/mL
Estimate against measurement, compound 3: 3.1-fold (0.49 log units) below, and the stated range ends below it.
By their numbers in this assay, from the lowest: compound 1; then compounds 3 and 2 (each within the scatter of the next).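

In this assay, thiomorpholin-4-yl and 4-acetylpiperazin-1-yl on this carbonyl carbon, whose other neighbour is an amide-type nitrogen in a ring, cannot be told apart: the change gives a 1.3-fold lower number from compound 2 to compound 3 (0.13 log units; within the scatter) and so stays inside the usual spread of repeat measurements. The rise over the cyclohexyl compound is thus no longer tied to 4-acetylpiperazin-1-yl alone, since thiomorpholin-4-yl in place of cyclohexyl gives a 7.2-fold higher number from compound 1 to compound 3 (0.86 log units; beyond the scatter) at the same carbonyl carbon, with the smaller of the two entering groups. Nothing measured here explains why these two groups read alike.

As far as these compounds go, whether a morpholine ring, a piperazine with a free amine or an open-chain dimethylamino group on this carbonyl carbon would read the same stays open. The compounds shown also leave open whether any ring is needed there at all.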